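The source may hold more compounds than are shown below. What is called first, only, known or untested is meant among the compounds shown, and "the series" means these compounds.

Measured in an ADME assay for pharmacokinetics, at pH 7.4; on this read-out higher numbers stand for a longer-lived compound and lower numbers for a shorter-lived compound:
Compound 1 `COc1ccnc(C[S+]([O-])c2nc3cc(OCC(F)(F)F)ccc3[nH]2)c1OC` gives > 200 h, a limit of the assay.
Compound 2 `COc1cnc(C[S+]([O-])c2nc3cc(OCC(F)(F)F)ccc3[nH]2)c(C)c1OC` gives 130 h.
Compound 3 `COc1ccnc(C[S+]([O-])c2nc3cc(OCC(F)(F)F)ccc3[nH]2)c1C` gives 5 h.

Compound 1 stands at the limit of > 200 h in this assay, at which 1 of the 3 values shown sits. From the compounds shown here alone, that figure is a limit and not a number, so how far the compound really lies beyond it remains unknown.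

The next compound, compound 4 `COc1ccnc(C[S+]([O-])c2nc3cc(OC(F)(F)C(F)F)ccc3[nH]2)c1OC`, differs from compound 1 in one place only: 1,1,2,2-tetrafluoroethyl in place of 2,2,2-trifluoroethyl on an oxygen on an aromatic ring. It carries 1,1,2,2-tetrafluoroethyl in place of 2,2,2-trifluoroethyl on an oxygen on an aromatic ring.

Two measured steps are at hand: an at least 40-fold lower number from compound 1 to compound 3 (1.60 log units; beyond the scatter) and a 26-fold lower number from compound 2 to compound 3 (1.41 log units; beyond the scatter). Both are large, so the read-out can clearly move a long way within this small set. Yet each of them exchanges a group on an aromatic carbon, and neither touches the chain on the oxygen. They therefore give no direct measure for the present change.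

Among the measured compounds shown here, with no step on that chain to go by, the expectation in this assay is for no clear change beyond the scatter. The step is estimated as a number no higher from compound 1 to compound 4 (the limit leaves the size open). A report as a limit alone would not be a surprise. Compound 4 is expected to give 200 h, with an estimated range from 80 h to 450 h.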

Compound 4, half-life: 160 h
Compound 4: middle estimate off by 1.3-fold (0.10 log units), on the high side, within the range that was stated.
By their numbers in this assay, from the lowest: compound 3; then compounds 2 and 4 (each within the scatter of the next). At a limit, above all of these: compound 1.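

Among the compounds shown here, compound 2 and compound 3 carry the same 2,2,2-trifluoroethyl chain as compound 1, so compound 4 gives the first reading of a change on the oxygen on an aromatic ring. In this assay, putting 1,1,2,2-tetrafluoroethyl in place of 2,2,2-trifluoroethyl gives an at least 1.2-fold lower number from compound 1 to compound 4 (0.09 log units; that floor lies within the scatter), a floor that does not establish a change, whereas the exchange of a group on an aromatic carbon gives an at least 40-fold lower number from compound 1 to compound 3 (1.60 log units; beyond the scatter). The true size of the new step remains unknown, and a large step is not ruled out, because the reading for compound 1 is a limit and not a number: the limit of > 200 h in this assay, at which 1 of the 4 values shown sits.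

The compounds shown leave open how a longer chain, such as a fluorinated propyl chain, or a non-fluorinated ethyl group would read on this oxygen. They also leave open whether 1,1,2,2-tetrafluoroethyl would give a similarly small step on the core of compound 3, which gives 5 h, where a shift in either direction could be read as a number.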